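The compounds below may be only part of what the source reports. "The series", "measured", "known", "first", "only" and "open" are said of these compounds alone.

Going by the values given here, compound 2, `COc1cc(C(=O)Nc2nn[nH]n2)nc(-c2ccccc2)c1`, is the stronger of the two compounds measured so far. In a functional assay on the whole organism with Rattus norvegicus as the target, at a dose of 3 mg/kg by the oral route (a higher number here means a stronger effect of the compound at the dose given, a lower number a weaker effect), compound 2 gives 97%, the highest of the two numbers, while compound 1, `CCCCc1ccc(-c2cc(Cl)cc(C(=O)Nc3nn[nH]n3)n2)cc1`, gives 83% in this assay, a difference beyond the usual scatter. Compound 3, `COc1cc(C(=O)Nc2nn[nH]n2)nc(-c2ccc(C)c(C)c2)c1`, has not yet been measured in this assay. Its structure differs from compound 2 in one place: 3,4-dimethylphenyl in place of phenyl on an aromatic carbon. Among the compounds with values here, no measured pair shows this change alone, so its effect is not known. Compound 2 already sits near the top of the scale, so compound 3 is expected to stay high, with a step of a number 7 percentage points lower from compound 2 to compound 3 (within the scatter) that may fall within the scatter. Compound 3 is therefore estimated at 90% in this assay, in a range from 75% to 99%.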

Compound 3, a percentage reported as inhibition, in the whole organism at one dose (the size of the read-out at that dose, not a potency): 82%
The estimate for compound 3 lay 8 percentage points above the measured number; the range from low to high includes it.
By their numbers in this assay, from the lowest: compounds 3 and 1 (each within the scatter of the next); then compound 2.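

In this assay, 3,4-dimethylphenyl in place of phenyl on the aromatic carbon next to the ring nitrogen gives a number 15 percentage points lower from compound 2 to compound 3 (beyond the scatter) at this dose. This position is therefore not indifferent to what its aromatic ring carries: with the rest of the structure unchanged, enlarging phenyl from 6 to 8 heavy atoms lowers the effect. No measurement given here explains this drop. Going by these compounds, it remains open whether a single methyl group would produce the same step, and how an amine or a carboxylic acid on this phenyl ring would compare.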